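From hydroxy to methoxy on the cyclohexyl group

The compounds below may be only part of what the source reports. "The series", "measured", "known", "first", "only" and "open" are said of these compounds alone.

Compound 1 `Cc1nc(-c2nc[nH]n2)ccc1-c1cnc2c(n1)N(CC1CCOCC1)C(=O)CN2`: 82 nM
Compound 2 `Cc1nc(-c2nc[nH]n2)ccc1-c1cnc2c(n1)N(C1CCOCC1)C(=O)CN2`: 102 nM
Compound 3 `Cc1nc(-c2nc[nH]n2)ccc1-c1cnc2c(n1)N([C@H]1CC[C@H](O)CC1)C(=O)CN2`: 119 nM

These values come from a functional assay on PC-3 cells (Homo sapiens) for inhibition, with a stated time of 72 h (a higher number here means a weaker inhibitor, a lower number a stronger inhibitor), where compound 3 lies within the scatter of the other two: a 1.2-fold higher number from compound 2 to compound 3 (0.07 log units; within the scatter) and a 1.5-fold higher number from compound 1 to compound 3 (0.16 log units; within the scatter). Compound 4 `CO[C@H]1CC[C@H](N2C(=O)CNc3ncc(-c4ccc(-c5nc[nH]n5)nc4C)nc32)CC1` differs from compound 3 by methyl in place of hydrogen on an oxygen on a saturated carbon. Among the compounds with values here, no measured step changes that oxygen. The closest evidence is the exchange of groups on the amide-type nitrogen in a ring, and those steps, including a 1.2-fold higher number from compound 1 to compound 2 (0.09 log units; within the scatter), stay within the scatter. No step beyond the scatter is therefore expected in this assay, and the expected change is a 1.1-fold lower number from compound 3 to compound 4 (0.03 log units; within the scatter). Compound 4 is estimated at 110 nM, with an expected range of 50 nM to 240 nM.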

Compound 4, half-maximal inhibitory concentration: 38 nM
For compound 4 the middle estimate is 2.9-fold (0.46 log units) above the measured one, outside the stated range (below it).
By their numbers in this assay, from the lowest: compound 4; then compounds 1, 2 and 3 (each within the scatter of the next).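

In this assay, within the data shown here, the change from hydroxy to methoxy brings a 3.1-fold lower number from compound 3 to compound 4 (0.50 log units; beyond the scatter), the first step beyond the scatter, so a single methyl on this oxygen counts for more than the earlier exchanges of groups on the amide-type nitrogen in a ring. The 4-methoxycyclohexyl group also stands apart from the other two groups, with a 2.7-fold lower number from compound 2 to compound 4 (0.43 log units; beyond the scatter) and a 2.2-fold lower number from compound 1 to compound 4 (0.33 log units; beyond the scatter) as its steps. Nothing available explains this difference.

Going by these compounds, whether an ethoxy group or an amine on that saturated carbon would hold the lower number remains open.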